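This account rests on a few compounds, and the source may have more. Where it says the series, first, only, none or still open, it means among the compounds named here.

Series notes. Compound 1 `Cc1cccc(/C(N)=N/NC(=S)N2CCN(c3ccccn3)CC2)n1`, compound 2 `N/C(=N\NC(=S)N1CCOCC1)c1ccccn1` and compound 3 `Cc1ccnc(/C(N)=N/NC(=S)N2CCOCC2)c1` share one core and have each been run in a functional assay on MCF7 cells (Homo sapiens) for cytotoxicity, read by MTT assay, with a stated time of 72 h, tested at 3 uM; a lower number here means less inhibition of growth, a higher number more inhibition of growth at the concentration tested. In this assay compound 2 gives 44.5%, compound 1 gives 27.1% and compound 3 gives 5.07%, the lowest of the three, set apart from both others by more than the scatter. Among the measured compounds shown here, the one single-point step measured so far, a number 39.4 percentage points lower from compound 2 to compound 3 (beyond the scatter), concerns a methyl on an aromatic carbon. Compound 4 `Cc1ccnc(/C(N)=N/NC(=S)N2CCSCC2)c1` differs from compound 3 by thiomorpholin-4-yl in place of morpholin-4-yl on a thiocarbonyl carbon. For the measured compounds named here, no measured step bears on this exchange; the methyl step between compound 2 and compound 3 has no connection to it. Expected in this assay is therefore a step not beyond the scatter, estimated as a number 4.9 percentage points higher from compound 3 to compound 4 (within the scatter). Estimated for compound 4 in this assay is 10%, with a range from 0% to 30%.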

Compound 4, percent growth inhibition at one concentration: 33.8%
Estimate against measurement, compound 4: 23.8 percentage points below; measured number outside the range, above it.
By their numbers in this assay, from the lowest: compound 3; then compounds 1 and 4 (each within the scatter of the next); then compound 2.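

In this assay the exchange on the thiocarbonyl carbon gives a number 28.7 percentage points higher from compound 3 to compound 4 (beyond the scatter) with thiomorpholin-4-yl in place of morpholin-4-yl. This position therefore responds to an exchange of oxygen for sulfur in the ring, even though the counts of heavy atoms, donors and acceptors stay the same. Nothing available explains this step.

From the compounds shown here alone, whether the same step appears without the methyl, on compound 2, remains open. So does the outcome with piperidin-1-yl or a dimethylamino group on the thiocarbonyl carbon.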